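The compounds below may be only part of what the source reports. "The series", "measured", "known", "first", "only" and "open" are said of these compounds alone.

Compound 2 `Nc1ccn([C@@H]2O[C@H](COP3(=O)OCC[C@H](c4cccnc4)O3)[C@@H](O)[C@@H]2O)c(=O)n1` is one of two measured members of a small set of cyclic phosphate prodrugs built on a shared nucleoside core. In a physicochemical assay for solubility, in phosphate buffer, at pH 7.4 (a higher number here means a more soluble compound, a lower number a less soluble compound), compound 2 gives 176000 ug/mL, and this is the only single number shown for any compound; the one other measured compound contributes an entry without a single number. That other compound is compound 1 `Nc1ccn([C@@H]2O[C@H](COP3(=O)OCC[C@H](c4ccncc4)O3)[C@@H](O)[C@@H]2O)c(=O)n1`. In this assay compound 1 gives 16700 ug/mL; > 200000 ug/mL (2 entries), as the several entries of compound 1 show (the several entries of compound 1 in this assay, 16700 ug/mL; > 200000 ug/mL (2 entries)). Compound 3 `COC(=O)c1cccc([C@H]2CCOP(=O)(OC[C@H]3O[C@@H](n4ccc(N)nc4=O)[C@@H](O)[C@@H]3O)O2)c1` has not yet been measured. It differs from compound 2 in one place: 3-(methoxycarbonyl)phenyl in place of pyridin-3-yl on a saturated ring carbon. For the measured compounds named here, no step between two measured compounds is available to calibrate this change, so the expectation rests only on the structural change itself. The step of a 2.9-fold lower number from compound 2 to compound 3 (0.47 log units; beyond the scatter) is expected to be downward and somewhat larger than the usual scatter of this assay. Compound 3 is therefore estimated to give 60000 ug/mL in this assay, with a plausible range from 15000 ug/mL to 200000 ug/mL.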

Compound 3, solubility: 7200 ug/mL
Beside the measured number, compound 3's estimate is 8.3-fold (0.92 log units) above it, outside the stated range (below it).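

In this assay, the saturated ring carbon next to the ring oxygen proved sensitive to the group it carries: 3-(methoxycarbonyl)phenyl in place of pyridin-3-yl gave a 24-fold lower number from compound 2 to compound 3 (1.39 log units; beyond the scatter), a large step beyond the scatter. For the compounds shown here, the earlier compounds offered no step between measured compounds, so this is the first measured size for any change at this position, and it shows that replacing pyridin-3-yl here need not leave the read-out near its former level. The size of this single step should still be read with some care, since the entries for compound 1 do not agree and one of them is a limit of the assay: the several entries of compound 1 in this assay, 16700 ug/mL; > 200000 ug/mL (2 entries)

The change removes the ring nitrogen and introduces the methoxycarbonyl group together, so the compounds shown cannot assign the step to either part of it. A plain phenyl group at this carbon would help separate the two, and a phenyl group bearing a carboxylic acid or an amine in place of the methyl ester would show whether the outcome depends on the substituent at that place.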